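Swapping the aryl group of compound 3 for a single fluorine

The source may hold more compounds than are shown below. What is called first, only, known or untested is meant among the compounds shown, and "the series" means these compounds.

Measured compounds:
- compound 1, `N#Cc1ccccc1-c1cnc(C(=O)CCCCCCc2ccccc2)o1`: 130 nM
- compound 2, `O=C(CCCCCCc1ccccc1)c1ncc(-c2ccc(O)cc2)o1`: 140 nM
- compound 3, `NS(=O)(=O)c1ccc(-c2cnc(C(=O)CCCCCCc3ccccc3)o2)s1`: 3 nM

All three values come from an assay (Rattus norvegicus) for inhibition of Fatty-acid amide hydrolase 1 (Homo sapiens); on this read-out lower numbers stand for stronger inhibition and higher numbers for weaker inhibition. Compound 3 gives the lowest number of the three: compound 1 is the nearest with a 43-fold lower number from compound 1 to compound 3 (1.64 log units; beyond the scatter) step separating them, and compound 2 is the furthest with a 47-fold lower number from compound 2 to compound 3 (1.67 log units; beyond the scatter). Compound 1 and compound 2 are within the scatter of each other, shown by a 1.1-fold higher number from compound 1 to compound 2 (0.03 log units; within the scatter).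

Compound 4, `O=C(CCCCCCc1ccccc1)c1ncc(F)o1`, has not yet been measured. It differs from compound 3 as follows: fluoro in place of 5-sulfamoylthiophen-2-yl on an aromatic carbon. Every measured step exchanges one aromatic group for another, and the two steps arriving at compound 3 are both large. Within the data shown here, no measured step removes the aromatic group altogether, so the change to compound 4 lies outside what the data cover. Since compound 3 is the lowest number and the large steps to it came from changing this very group, compound 4 is expected to move toward a higher number, roughly a 200-fold higher number from compound 3 to compound 4 (2.30 log units; beyond the scatter). Compound 4 is therefore estimated at 600 nM in this assay, within a range from 150 nM to 2500 nM.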

Compound 4, inhibition constant: 30 nM
For compound 4 the middle estimate is 20-fold (1.30 log units) above the measured one; measured number below the stated range.
By their numbers in this assay, from the lowest: compound 3; then compound 4; then compounds 1 and 2 (each within the scatter of the next).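

In this assay, this position does not need an aromatic ring to give a low number: replacing the 5-sulfamoylthiophen-2-yl with a single fluorine gives only a modest loss (a 10-fold higher number from compound 3 to compound 4 (1.00 log units; beyond the scatter)). The one-atom fluoro also gives lower numbers than two far larger groups, the 4-hydroxyphenyl (a 4.7-fold lower number from compound 2 to compound 4 (0.67 log units; beyond the scatter)) and the 2-cyanophenyl (a 4.3-fold lower number from compound 1 to compound 4 (0.64 log units; beyond the scatter)), so among these compounds a ring here can either raise or lower the number relative to fluoro, and group size alone does not set the order. Nothing available gives a reason for this order.

As far as these compounds go, it remains open whether the fluorine itself contributes, which a plain hydrogen, a chlorine or a methyl on this carbon would test. From the compounds shown here alone, it is also open whether compound 3 owes its low number to the thiophene or to the sulfamoyl group, which an unsubstituted thiophen-2-yl and a 4-sulfamoylphenyl could separate.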